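The compounds below may be only part of what the source reports. "The series", "measured", "known", "first", "only" and "open" are said of these compounds alone.

Working notes on the series in an ADME assay on HepG2 cells (Homo sapiens) for cytotoxicity, read by luminescence, CellTiter-Glo and ATP content, with a stated time of 72 h; on this read-out lower numbers stand for an effect already at smaller amounts and higher numbers for an effect only at larger amounts of compound: compound 1 `COc1ccc(F)cc1CNCCCNc1ccnc2cc(Cc3ccc(C#N)cc3)ccc12` gives 6050 nM and compound 2 `COc1ccc(F)cc1CNCCCNc1ccnc2cc(Oc3ccc(F)cc3)ccc12` gives 6600 nM while compound 3 `COc1ccc(-c2ccc3c(NCCCNCc4cc(F)ccc4OC)ccnc3c2)cc1` gives 5960 nM on the same read-out. Compound 3 stands level with the other two. The steps that reach it are small: a 1.0-fold lower number from compound 1 to compound 3 (0.01 log units; within the scatter) and a 1.1-fold lower number from compound 2 to compound 3 (0.04 log units; within the scatter) are the whole of its movement, and a 1.1-fold higher number from compound 1 to compound 2 (0.04 log units; within the scatter) likewise stays inside the scatter. Three different groups on the same aromatic carbon have therefore given no separation so far.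

Compound 4 `COc1ccc(F)cc1CNCCCNc1ccnc2cc(Oc3ccc(C(C)(C)C)cc3)ccc12` has not been measured. The change from compound 3 is 4-(tert-butyl)phenoxy in place of 4-methoxyphenyl on an aromatic carbon with 4-(tert-butyl)phenoxy in place of 4-methoxyphenyl on an aromatic carbon. Going by the values given here, no measured compound carries a tert-butyl group, so that part of the change remains untested. The 4-fluorophenoxy of compound 2 is the nearest measured group to the one entering.

No step beyond the scatter is expected in this assay because a 1.1-fold lower number from compound 2 to compound 3 (0.04 log units; within the scatter) is the closest measured swap, and no direction is favoured. The step expected is a 1.1-fold lower number from compound 3 to compound 4 (0.03 log units; within the scatter) on this estimate. The estimated value for compound 4 is 5500 nM with an expected range from 2500 nM to 11000 nM on this read-out.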

Compound 4, half-maximal effective concentration: 7200 nM
Compound 4: the middle estimate sits 1.3-fold (0.12 log units) below what was measured; low and high end bracket the measured number.
By their numbers in this assay, from the lowest: compounds 3, 1, 2 and 4 (each within the scatter of the next).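

In this assay, the 4-(tert-butyl)phenoxy group extends to a fourth group the flat response at this aromatic carbon, which is para to a fused ring: a 1.2-fold higher number from compound 3 to compound 4 (0.08 log units; within the scatter) and a 1.2-fold higher number from compound 1 to compound 4 (0.08 log units; within the scatter) both remain inside the scatter. The closest comparison, tert-butyl in place of fluoro on an aromatic carbon, gives a 1.1-fold higher number from compound 2 to compound 4 (0.04 log units; within the scatter), so this outer substituent on the phenoxy ring produces no separation either, and the entering group's 11 heavy atoms against the 8 of the leaving 4-methoxyphenyl likewise bring no step beyond the scatter. Nothing available here accounts for this flat response.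

Open, going by these compounds, is whether the flat response extends to groups of a different kind on this aromatic carbon, such as a primary amine or a carboxylic acid, in place of the aromatic substituents seen so far. Also open, on these data alone, is whether cytotoxicity in these cells responds to changes elsewhere in the molecule, for instance a longer chain in place of the side chain that all four compounds share.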